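Two limits and a fluoro-nitro swap

The source may report more compounds than this note shows. Statements on the series, on what has been measured and on what is new or still open speak of the compounds shown alone.

Compound 1 `O=C(O)c1ccc(C(=O)/C(=C\c2ccc(O)c([N+](=O)[O-])c2)SCc2ccc(Br)cc2)cc1` - < 1000 ug/mL (a limit)
Compound 2 `O=C(O)c1ccc(C(=O)/C(=C\c2ccc(Cl)c([N+](=O)[O-])c2)SCc2ccc(Br)cc2)cc1` - < 1000 ug/mL (a limit)

In a physicochemical assay for solubility (a lower number here means a less soluble compound, a higher number a more soluble compound), compound 2 stands only at a limit, < 1000 ug/mL. Both measured compounds rest on (the limit of < 1000 ug/mL in this assay, at which 2 of the 2 values shown sit). Compound 3 `O=C(O)c1ccc(C(=O)/C(=C\c2ccc([N+](=O)[O-])c(F)c2)SCc2ccc(Br)cc2)cc1` carries 3-fluoro-4-nitrophenyl in place of 4-chloro-3-nitrophenyl, on a double-bonded chain carbon bound to a double-bonded chain carbon: 3-fluoro-4-nitrophenyl in place of 4-chloro-3-nitrophenyl on a double-bonded chain carbon bound to a double-bonded chain carbon. For the measured compounds named here, the one measured step that bears on this is a step that the two limits leave unreadable from compound 1 to compound 2, and it offers no size to carry over, so no step beyond the scatter is expected. The expected step is a step that the limit leaves unreadable from compound 2 to compound 3. Another limit is also the likely report. For compound 3 the estimate in this assay is 200 ug/mL, with an expected range of 20 ug/mL to 1000 ug/mL.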

Compound 3, solubility: < 1000 ug/mL
Compound 3: no number, only a limit; the forecaster's own chance of this, stated with the estimate: 85%; the middle value is on the limit's open side.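

In this assay, for the compounds shown here, compound 3 gives only a limit, and no step among compound 1, compound 2 and compound 3 can be read: the limit of < 1000 ug/mL in this assay, at which 3 of the 3 values shown sit. The compounds shown leave open the actual solubility of all three, and whether 3-fluoro-4-nitrophenyl in place of 4-chloro-3-nitrophenyl changes it at all.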